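The source may report more compounds than this note shows. Statements on the series, on what has been measured and on what is new or still open speak of the compounds shown alone.

Within the data shown here, compound 1, `CC1(Cc2ccccc2)CC(S(=O)(=O)c2ccc(F)cc2)=C(c2ccc(/C(N)=N/O)cc2)O1`, gives in an ADME assay on cells (Peritoneal macrophage, Mus musculus, strain Balb/c) for cytotoxicity, read by resazurin assay, with a stated time of 72 h (on this read-out lower numbers stand for higher toxicity in this test and higher numbers for lower toxicity in this test), a value of 102000 nM, the highest of the two numbers measured so far, though the step to its only neighbour lies within the scatter. That neighbour is compound 2, `CC1(Cc2cccc([N+](=O)[O-])c2)CC(S(=O)(=O)c2ccc(F)cc2)=C(c2ccc(/C(N)=N/O)cc2)O1`, which in this assay gives 86600 nM; the step is a 1.2-fold lower number from compound 1 to compound 2 (0.07 log units; within the scatter). Compound 3, `Cc1ccccc1CC1(C)CC(S(=O)(=O)c2ccc(F)cc2)=C(c2ccc(/C(N)=N/O)cc2)O1`, differs from compound 1 by methyl in place of hydrogen on an aromatic carbon, which read one bond further out is benzyl to 2-methylbenzyl. Among the measured compounds shown here, the single measured step that bears on this change is the one from compound 1 to compound 2, a substitution on the same benzyl ring, and it stayed within the scatter. No step beyond the scatter is therefore expected in this assay for compound 3. Compound 3 is estimated at 100000 nM, with a range from 50000 nM to 200000 nM. The expected step, a 1.0-fold lower number from compound 1 to compound 3 (0.01 log units; within the scatter), is essentially none beyond the scatter.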

Compound 3, half-maximal cytotoxic concentration: 77600 nM
Beside the measured number, compound 3's estimate is 1.3-fold (0.11 log units) above it, within the range that was stated.
By their numbers in this assay, from the lowest: compounds 3, 2 and 1 (each within the scatter of the next).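

In this assay, methyl in place of hydrogen on an aromatic carbon, ortho to a large group, gives a 1.3-fold lower number from compound 1 to compound 3 (0.12 log units; within the scatter) and so stays within the scatter, which extends what the nitro compound showed to a second substituent and a second place on the same ring. Putting 2-methylphenyl in place of 3-nitrophenyl gives a 1.1-fold lower number from compound 2 to compound 3 (0.05 log units; within the scatter) and also stays within the scatter, so none of the three compounds stands apart from the others on this read-out. Nothing available explains these numbers.

From the compounds shown here alone, whether an amine or a carboxylic acid on this ring would also stay within the scatter in this assay remains open. So does the effect of a longer chain, such as propyl, in place of the methyl at this place.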